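A fluoro swap at the edge of an assay limit

This account rests on a few compounds, and the source may have more. Where it says the series, first, only, none or still open, it means among the compounds named here.

- Compound 1 `CC(C)COc1ncc(-c2cn(C)c3cc(C(=O)NS(C)(=O)=O)ccc23)cc1Cl` gives < 0.001 as a limit
- Compound 2 `Cn1nc(-c2ccc(C(F)(F)F)cc2)c2cc(F)c(C(=O)NS(=O)(=O)C3CC3)cc21` gives "not determined" (no result reported) as its entry

In an ADME assay on a cell-free system (plasma, Homo sapiens) for protein binding (on this read-out higher numbers stand for a larger free fraction and lower numbers for a smaller free fraction), compound 1 gives < 0.001 which is a limit of the assay and not a number. Compound 2 offers no number for comparison. Compound 3 `CC(C)COc1ncc(-c2cn(C)c3cc(C(=O)NS(C)(=O)=O)c(F)cc23)cc1Cl` keeps the core of compound 1 but has fluoro in place of hydrogen on an aromatic carbon, ortho to a (methylsulfonyl)carbamoyl group fluoro in place of hydrogen on an aromatic carbon on the ring of carbon only. Among the measured compounds shown here, no measured pair shows what this swap does here. The expected step is a step that the limit leaves unreadable from compound 1 to compound 3 and it is not expected to pass the scatter in either direction. Compound 3 is estimated at 0.0008 with a range from 0.0003 to 0.002 in this assay and a limit instead of a number is also expected for it.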

Compound 3, unbound fraction: 0.001
Estimate against measurement, compound 3: 1.3-fold (0.10 log units) below; the range from low to high includes it.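

Fluoro in place of hydrogen on this aromatic carbon, ortho to a (methylsulfonyl)carbamoyl group, yields a measured number in this assay, whereas compound 1 gives only a limit of the assay. The step is a number no lower from compound 1 to compound 3 (the limit leaves the size open). Its size cannot be read because one end of it is a limit: the limit of < 0.001 in this assay, at which 1 of the 3 values shown sits.

The compounds shown leave open whether chloro or methyl on this same carbon would give a readable change in free fraction. They also leave open what a carboxylic acid in place of the (methylsulfonyl)carbamoyl group would do.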